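Switching methoxy for nitro on a cytotoxicity series

This account rests on a few compounds, and the source may have more. Where it says the series, first, only, none or still open, it means among the compounds named here.

Measured so far, in a functional assay on HepG2 cells (Homo sapiens) for cytotoxicity, read by sulforhodamine B assay, with a stated time of 48 h; a higher number here means a weaker inhibitor, a lower number a stronger inhibitor:
- Compound 1, `C/C(=N\NC(=O)/C(C#N)=C/N(C)C)c1ccc(NS(=O)(=O)c2ccc(Cl)cc2)cc1`, gives 19400 nM.
- Compound 2, `CCOC(=O)c1c(-c2ccc(OC)cc2)c(C#N)c(=O)n(/N=C(\C)c2ccc(NS(=O)(=O)c3ccc(Cl)cc3)cc2)c1N`, gives 61700 nM.

Of the two numbers seen, compound 2 stands at the highest, and so is the weaker of the pair; the nearest point is compound 1, whose number is lower by an amount beyond the scatter. Compound 3, `CCOC(=O)c1c(-c2ccc([N+](=O)[O-])cc2)c(C#N)c(=O)n(/N=C(\C)c2ccc(NS(=O)(=O)c3ccc(Cl)cc3)cc2)c1N`, is not yet measured. It differs from compound 2 in one place: nitro in place of methoxy on an aromatic carbon. Within the data shown here, no measured pair shows this particular swap, so nothing within the data tells how far the number should move. In the absence of such a reference, the expectation is a step from compound 2 to compound 3 of about a 1.2-fold lower number from compound 2 to compound 3 (0.09 log units; within the scatter), which amounts to no change beyond the scatter. Compound 3 is therefore estimated at 50000 nM, with a range from 15000 nM to 150000 nM.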

Compound 3, half-maximal inhibitory concentration: 41100 nM
Compound 3: the middle estimate sits 1.2-fold (0.09 log units) above what was measured, and the stated range covers the measured number.
By their numbers in this assay, from the lowest: compound 1; then compounds 3 and 2 (each within the scatter of the next).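

Placing nitro where methoxy stood, on an aromatic carbon para to a large group, gives a 1.5-fold lower number from compound 2 to compound 3 (0.18 log units; within the scatter) in this assay and so produces no readable difference. Among these compounds, this is the first pair that differs in one place only, and it shows that 4-methoxyphenyl and 4-nitrophenyl cannot be told apart in this read-out. No supporting measurement on these two groups is available to interpret that result.

Going by these compounds, whether an amine, a carboxylic acid or a plain hydrogen at the same position would shift the number beyond the scatter remains open. On these data alone, it is also open whether the same swap would give a similar result on a different part of the molecule, or on a core like that of compound 1.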